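A few compounds are considered here, and "the series" means these few. Any claim that something is new, unique, unknown or untested is made for them only; others in the source may bear on it.

Compound 1 `O=C(N/N=C/c1ccc(F)cc1)Nc1cc2c(Nc3ccc(F)c(Cl)c3)ncnc2cc1O[C@H]1CCOC1`: "not active" (no number reported)
Compound 2 `COc1cc(/C=N/NC(=O)Nc2cc3c(Nc4ccc(F)c(Cl)c4)ncnc3cc2O[C@H]2CCOC2)cc(OC)c1OC`: 31200 nM

Among the compounds with values here, in a functional assay on HepG2 cells (Homo sapiens) for cytotoxicity, read by MTT assay, with a stated time of 72 h (a lower number here means a stronger inhibitor, a higher number a weaker inhibitor), compound 2 gives 31200 nM, the only number available, since compound 1 has none. Compound 3 `CCN(CC)c1ccc(/C=N/NC(=O)Nc2cc3c(Nc4ccc(F)c(Cl)c4)ncnc3cc2O[C@H]2CCOC2)c(O)c1` shares their core but carries 4-(diethylamino)-2-hydroxyphenyl in place of 3,4,5-trimethoxyphenyl on a carbon with a double bond to nitrogen. Within the data shown here, no measured step shows what such a swap does, so this forecast is loose. A moderate move toward a stronger inhibitor seems likely, although a result within the scatter would be no surprise. The expected change is a 2.1-fold lower number from compound 2 to compound 3 (0.32 log units; beyond the scatter). For compound 3, the estimate is 15000 nM, with an expected range of 3000 nM to 60000 nM.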

Compound 3, half-maximal inhibitory concentration: 15700 nM
Estimate against measurement, compound 3: 1.0-fold (0.02 log units) below; measured number inside the range.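

In this assay, the change from 3,4,5-trimethoxyphenyl to 4-(diethylamino)-2-hydroxyphenyl on a carbon with a double bond to nitrogen gives a 2.0-fold lower number from compound 2 to compound 3 (0.30 log units; within the scatter). This first readable step at this position shows that two differently substituted rings can be exchanged there without a result beyond the scatter. No measurement of any property of these groups is available to explain the step.

The compounds shown leave open whether a simple 2-hydroxyphenyl or 4-(diethylamino)phenyl group would read the same. On these data alone, a pyridine ring at this position also remains untested here.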